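Hydrogen in place of methyl on compound 2

The source may hold more compounds than are shown below. What is called first, only, known or untested is meant among the compounds shown, and "the series" means these compounds.

Measured values in an ADME assay for permeability (a higher number here means that the compound crosses the layer faster, a lower number that the compound crosses the layer more slowly), so far:
compound 1 (`CNC(=O)c1cc(C(=O)NCCO)n([C@@H](C)c2ccccc2)n1`) gives 59 nm/s
compound 2 (`CNC(=O)c1cc(C(=O)N[C@H]2CC[C@H](O)CC2)c([C@@H](C)c2cccc(C)c2)o1`) gives 85 nm/s

Compound 2 at 85 nm/s and compound 1 at 59 nm/s lie within the usual scatter of each other, so the two numbers set no order. Compound 3 (`CNC(=O)c1cc(C(=O)N[C@H]2CC[C@H](O)CC2)c([C@@H](C)c2ccccc2)o1`) differs from compound 2 in one place (hydrogen in place of methyl on an aromatic carbon), with hydrogen in place of methyl on an aromatic carbon, which reads as 3-methylphenyl to phenyl. Among the measured compounds shown here, no measured pair shows this change, so this assay gives no direct guide to its size. For the measured compounds named here, the only close anchor is compound 2 itself. The expected 1.2-fold lower number from compound 2 to compound 3 (0.07 log units; within the scatter) is a small one, and no change beyond the scatter is anticipated. Compound 3 is expected at 72 nm/s with an estimated range from 36 nm/s to 140 nm/s around that middle.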

Compound 3, apparent permeability: 42 nm/s
The estimate for compound 3 lay 1.7-fold (0.23 log units) above the measured number; low and high end bracket the measured number.
By their numbers in this assay, from the lowest: compounds 3, 1 and 2 (each within the scatter of the next, the first and the last beyond it).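

In this assay, among the compounds shown here, the change from 3-methylphenyl to phenyl gives a 2.0-fold lower number from compound 2 to compound 3 (0.31 log units; beyond the scatter) and so provides the first direct reading at this position, on an aromatic carbon meta to a large group. The step is modest and rests on a single pair, yet it shows that this one methyl is not silent in the read-out. Nothing on hand accounts for the step.

Going by these compounds, it remains open whether a different group at this position, such as an ethyl, a methoxy, a chlorine or an amine, would give a number above or below that of compound 3. On these data alone, it also remains open whether adding the same methyl to the 1-phenylethyl group on the core of compound 1 would produce a step of similar size and direction.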